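Adding a chloro group to compound 1

The source may hold more compounds than are shown below. What is called first, only, known or untested is meant among the compounds shown, and "the series" means these compounds.

Compound 1 `O=C1NC(=S)/C(=C/c2ccc(Cl)cc2)S1`: 28.6%
Compound 2 `O=C1NC(=S)/C(=C/c2ccc(F)cc2)S1`: 17.5%
Compound 3 `O=C1NC(=S)/C(=C/c2ccc(Cl)c(Cl)c2)S1`: 19.4%

All three numbers come from a functional assay on NCI-H292 cells (Homo sapiens) for cytotoxicity, read by MTT assay, with a stated time of 72 h, tested at 2.5 ug/mL; on this read-out lower numbers stand for less inhibition of growth and higher numbers for more inhibition of growth at the one concentration tested. Compound 1 serves as the reference here. The nearest number lies at a number 9.2 percentage points lower from compound 1 to compound 3 (within the scatter), and the furthest lies at a number 11.1 percentage points lower from compound 1 to compound 2 (beyond the scatter).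

Compound 4 `O=C1NC(=S)/C(=C/c2ccc(Cl)cc2Cl)S1` has not yet been measured. Its structure departs from that of compound 1 by one change, (chloro in place of hydrogen on an aromatic carbon), which is chloro in place of hydrogen on an aromatic carbon.

Within the data shown here, only one measured step is of this same kind, namely a number 9.2 percentage points lower from compound 1 to compound 3 (within the scatter). The other step, a number 11.1 percentage points lower from compound 1 to compound 2 (beyond the scatter), is fluoro in place of chloro on an aromatic carbon, so it bears on the question only loosely. Among the measured compounds shown here, three compounds offer thin evidence, and the single matching step does not settle how the new place on the ring will behave. A small fall would fit that matching step, but no step beyond the scatter is expected in this assay. The expected step is a number 5.6 percentage points lower from compound 1 to compound 4 (within the scatter). For compound 4 the estimated value is 23%, with an expected range from 12% to 35%.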

Compound 4, percent growth inhibition at one concentration: 14.7%
Compound 4: the middle estimate sits 8.3 percentage points above what was measured; the range from low to high includes it.
By their numbers in this assay, from the lowest: compounds 4, 2, 3 and 1 (each within the scatter of the next, the first and the last beyond it).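

In this assay, among these compounds, chloro in place of hydrogen on an aromatic carbon, ortho to a group of 8 heavy atoms and meta to a chloro group, gives a number 13.9 percentage points lower from compound 1 to compound 4 (beyond the scatter), the first step of this kind to stand clear of the scatter, whereas the same change at the other place on the ring gave a number 9.2 percentage points lower from compound 1 to compound 3 (within the scatter). This does not yet set the two places apart, since compound 3 at 19.4% and compound 4 at 14.7% lie within the scatter of each other, so the series shows only that a second chloro does not raise the number at either place. Nothing at hand speaks to why this step takes the size it does.

From the compounds shown here alone, it remains open whether another group at this same place, such as a methoxy group, an amine or a carboxylic acid, would give a number closer to that of compound 1 or go lower still. Each compound is also described at a single concentration, so these numbers leave open how the compounds would compare across a range of concentrations.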